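Phenyl in Place of Propyl: Expectation for Compound 3

The compounds below may be only part of what the source reports. "The series", "measured", "known", "first", "only" and "open" are said of these compounds alone.

Measured compounds:
compound 1, `CCCCOC(=O)NS(=O)(=O)c1ccc(CCC)cc1-c1ccc(Cn2c(-c3nccs3)nc3ccccc32)cc1`: 5.1 nM
compound 2, `CCCCOC(=O)NS(=O)(=O)c1ccc(CCC)cc1-c1ccc(Cn2c(CCCC)nc3ccccc32)cc1`: 9.2 nM

In an assay on membranes from HEK293 cells for displacement of a labelled ligand from Type-2 angiotensin II receptor (Homo sapiens), read by radioligand binding (on this read-out higher numbers stand for weaker inhibition and lower numbers for stronger inhibition), compound 1 gives 5.1 nM, and compound 2 gives 9.2 nM. Among the measured compounds shown here, the single measured step, a 1.8-fold higher number from compound 1 to compound 2 (0.26 log units; within the scatter), exchanged one group on the aromatic carbon of the shared core and stayed within the scatter. Compound 2 therefore carries the numerically higher of the two numbers, but it cannot be separated from compound 1 on these data.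

Compound 3, `CCCCOC(=O)NS(=O)(=O)c1ccc(CCC)cc1-c1ccc(Cn2c(Cc3ccccc3)nc3ccccc32)cc1`, follows from compound 2 by phenyl in place of propyl on a saturated chain carbon bound to an aromatic carbon. For the measured compounds named here, no measured step matches this change; the only one available, a 1.8-fold higher number from compound 1 to compound 2 (0.26 log units; within the scatter), concerns the same part of the molecule and showed no movement beyond the scatter. With a six-membered aromatic ring entering where compound 1 already carried an aromatic ring without loss, the step of a 1.3-fold lower number from compound 2 to compound 3 (0.12 log units; within the scatter) is expected to remain small, if anything toward a lower number. Compound 3 is estimated at 7 nM, with a range from 2.5 nM to 25 nM.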

Compound 3, inhibition constant: 15 nM
Compound 3: middle estimate off by 2.1-fold (0.33 log units), on the low side; the measured number falls inside the stated range.
By their numbers in this assay, from the lowest: compounds 1, 2 and 3 (each within the scatter of the next, the first and the last beyond it).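

In this assay, phenyl in place of propyl on a saturated chain carbon bound to an aromatic carbon, which reads as butyl to benzyl when cut one bond further out, gives a 1.6-fold higher number from compound 2 to compound 3 (0.21 log units; within the scatter) and so leaves compound 3 inseparable from compound 2 on these data, showing that this position accepts a six-membered aromatic ring of carbon at the end of the chain with no movement beyond the scatter. The same position now also gives its first difference beyond the scatter, though a modest one: a 2.9-fold higher number from compound 1 to compound 3 (0.47 log units; beyond the scatter) in this assay. Nothing available bears on why these numbers fall as they do.

The compounds shown leave open how this position would respond to a chain longer than butyl, or to an amine or a carboxylic acid in place of benzyl. They also leave open where phenyl itself, set directly on the aromatic carbon that carries 1,3-thiazol-2-yl in compound 1, would fall on this read-out.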